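Working notes: nitro to chloro in a short cytotoxicity series

The compounds below may be only part of what the source reports. "The series", "measured", "known", "first", "only" and "open" are said of these compounds alone.

Measured in a functional assay on MCF7 cells (Homo sapiens) for cytotoxicity, read by MTT assay, with a stated time of 48 h; on this read-out higher numbers stand for weaker inhibition and lower numbers for stronger inhibition:
- compound 1, `C/C(=N/NC(=S)Nc1ccc(Cl)cc1)c1ccccn1`: compound 1 gives 8.49 nM
- compound 2, `C/C(=N/NC(=S)Nc1ccccc1[N+](=O)[O-])c1ccccn1`: compound 2 gives 5.7 nM
- compound 3, `C/C(=N/NC(=S)Nc1ccc([N+](=O)[O-])cc1)c1ccccn1`: compound 3 gives 52 nM

Compound 2 and compound 1 fall within the scatter of each other in this assay; compound 3 sits beyond the scatter above both. Compound 2 and compound 3 have the same atoms joined differently; the difference between the two cores is not broken down here.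

One change is measured directly: chloro in place of nitro on an aromatic carbon. It made the step of a 6.1-fold lower number from compound 3 to compound 1 (0.79 log units; beyond the scatter).

Compound 4, `C/C(=N/NC(=S)Nc1ccccc1Cl)c1ccccn1`, is not yet measured in this assay. It relates to compound 2 as compound 1 relates to compound 3: chloro in place of nitro on an aromatic carbon. The two places are not the same word for word: in compound 3 the leaving nitro sits para to a large group, in compound 2 it sits ortho to a large group, so this is the same kind of change, not the same change. Going by the values given here, only one example of the change exists, so its transfer to the ortho place is uncertain.

Compound 4 is expected to give a lower number than compound 2 because compound 3 to compound 1 made the step of a 6.1-fold lower number from compound 3 to compound 1 (0.79 log units; beyond the scatter), and the estimated step is a 2.3-fold lower number from compound 2 to compound 4 (0.36 log units; beyond the scatter), taken smaller than that single step since the place differs and compound 2 already gives 5.7 nM. The estimate for compound 4 is 2.5 nM, with a range from 0.8 nM to 8 nM.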

Compound 4, half-maximal inhibitory concentration: 0.16 nM
For compound 4 the middle estimate is 16-fold (1.19 log units) above the measured one; the whole stated range lies above it.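

In this assay, chloro in place of nitro on an aromatic carbon again lowers the number, with a 36-fold lower number from compound 2 to compound 4 (1.55 log units; beyond the scatter), so the direction of the change is the same on both cores shown and the step is large on the second. The size of the step does not carry over, and a value read from one core would not have given the value on the other: the same change on two cores in this assay, a 6.1-fold lower number (0.79 log units; beyond the scatter) from compound 3 to compound 1 and a 36-fold lower number (1.55 log units; beyond the scatter) from compound 2 to compound 4, 5.8-fold (0.76 log units) apart, beyond the scatter of two such steps These two pairs show that the direction held in both available cases, but they do not give a general rule, and they do not explain why the step differs, since the core and the place of the change, here ortho to a large group, are not separated by any pair shown.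

The compounds shown leave open whether other groups on this aromatic carbon, such as methoxy, fluoro or an amine, would give numbers close to those of chloro or of nitro. Also open, as far as these compounds go, is whether the chloro for nitro step would keep its direction, or either of its sizes, with a longer chain elsewhere on the shared core.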